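The source may report more compounds than this note shows. Statements on the series, on what has been measured and on what is new or still open speak of the compounds shown alone.

Measured so far in a functional assay on KB cells (Homo sapiens) for inhibition, read by MTT assay, with a stated time of 24 h, tested at 10 ug/mL; on this read-out lower numbers stand for less inhibition of growth and higher numbers for more inhibition of growth at the one concentration tested:
- compound 1 `CC(=O)SCCC(CCCCC(=O)O)SC(C)=O`: 8.88%
- compound 2 `O=C(CCCCC1CCSS1)Nc1ccc([N+](=O)[O-])c(C(F)(F)F)c1`: "not active" (no number reported)
- compound 3 `O=C(CCCCC1CCSS1)Nc1ccc(Cl)cn1`: 28.6%

Only two of these compounds have a number, and compound 1, at 8.88%, holds the lower one. Compound 3, at 28.6%, lies higher, and that gap is beyond the usual scatter. Compound 2 gave no number at all.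

The next compound is compound 4 `CC(=O)SCCC(CCCCC(=O)Nc1cccc(Cl)c1)SC(C)=O`. It keeps the core of compound 1 and replaces one group: (3-chlorophenyl)amino stands in place of hydroxy on a carbonyl carbon ((3-chlorophenyl)amino in place of hydroxy on a carbonyl carbon). Among the compounds with values here, no two measured compounds differ in just one place, so no measured step can guide this estimate directly.

The closest hints are indirect. Compounds 2 and 3 also carry a ring-bearing amino group on a carbonyl carbon, but their other end differs from that of compound 1. In this assay, compound 3 reached 28.6%, which points upward, while compound 2 gave "not active" (no number reported), which argues for caution.

A modest rise is therefore expected, estimated as a number 11.1 percentage points higher from compound 1 to compound 4 (beyond the scatter), and it may not clear the scatter by much. For compound 4 the expected value is 20%, with an estimated range of 5% to 45%.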

Compound 4, percent growth inhibition at one concentration: "not active" (no number reported)
For compound 4 the study gives words and no number; no gap can be computed for the estimate.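

In this assay, within the data shown here, compound 4 gives "not active" (no number reported) and so no step from compound 1 to compound 4 can be read. No measurement shown here offers an explanation for this result. The compounds shown leave open how (3-chlorophenyl)amino in place of hydroxy on a carbonyl carbon changes growth inhibition in numbers.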